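The source may hold more compounds than are shown below. What is called first, only, known or untested is meant among the compounds shown, and "the series" means these compounds.

Compound 1 `CCO/N=C(\CCN1CCN(c2ccccc2C#N)CC1)c1ccccc1` and compound 2 `CCO/N=C(\CCN1CCN(c2ccccc2OC)CC1)c1ccccc1` share one core and differ only in the group on an aromatic carbon. In a functional assay on HEK293 cells with D(4) dopamine receptor (Homo sapiens) as the target, read by FLIPR (a lower number here means a smaller maximal response, a higher number a larger maximal response), compound 1 gives 82%, and in this assay compound 2 gives 76%. The step of a number 6 percentage points lower from compound 1 to compound 2 (within the scatter) lies within the scatter, so compound 2 stands level with compound 1 on the two numbers shown. Compound 3 `CCO/N=C(\CCN1CCN(c2cccc(OC)c2)CC1)c1ccccc1` differs from compound 2 by 3-methoxyphenyl in place of 2-methoxyphenyl on an amine nitrogen in a ring. Among the compounds with values here, the single measured step exchanges cyano for methoxy on an aromatic carbon; no measured step exchanges a 2-methoxyphenyl for a 3-methoxyphenyl, so none bears directly on this change, and the data give no direction for it. Compound 3 is therefore expected to show no step beyond the scatter, the estimated step being a number 1 percentage points lower from compound 2 to compound 3 (within the scatter). Compound 3 is estimated at 75% in this assay, with a range from 50% to 95%.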

Compound 3, largest response reached (reported as efficacy), in percent of the reference or control that the assay uses: 30%
For compound 3 the middle estimate is 45 percentage points above the measured one; measured number outside the range, below it.
By their numbers in this assay, from the lowest: compound 3; then compounds 2 and 1 (each within the scatter of the next).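

The earlier pair changed only the group, and 2-cyanophenyl and 2-methoxyphenyl stood level. Compound 3 shows that the place of the methoxy on the phenyl counts for far more in this assay: with the same atoms joined differently, the result is a number 46 percentage points lower from compound 2 to compound 3 (beyond the scatter). The exchange against the nitrile-bearing phenyl gives a number 52 percentage points lower from compound 1 to compound 3 (beyond the scatter), so among these three compounds the two 2-substituted phenyls keep a high maximal response and the 3-methoxyphenyl alone loses most of it; nothing available explains this loss.

As far as these compounds go, it remains open whether the drop belongs to the methoxy itself or would also come with a chlorine, a methyl or a nitrile on a 3-substituted phenyl. From the compounds shown here alone, what 4-methoxyphenyl or an unsubstituted phenyl would give also remains open.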